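This account rests on a few compounds, and the source may have more. Where it says the series, first, only, none or still open, it means among the compounds named here.

Three amides built on a shared core have been measured in a functional assay on HCT-116 cells (Homo sapiens) for antiproliferative activity, read by MTT assay, with a stated time of 72 h; on this read-out lower numbers stand for stronger inhibition and higher numbers for weaker inhibition. Compound 1 `O=C(CCc1cccc2c1B(O)OC2)NC1CCCCC1` carries a cyclohexyl group on the amide nitrogen. In this assay compound 1 reaches only > 100000 nM, a limit of the assay rather than a number (the limit of > 100000 nM in this assay, at which 1 of the 3 values shown sits). Compound 2 `Cc1ccc(NC(=O)CCc2cccc3c2B(O)OC3)cc1` gives 4500 nM in this assay, and compound 3 `O=C(CCc1cccc2c1B(O)OC2)Nc1cccc(I)c1` gives 2300 nM. Of the two numbers shown, compound 3 has the lowest, yet the gap to its neighbour is a 2.0-fold lower number from compound 2 to compound 3 (0.29 log units; within the scatter), within the scatter, so the two cannot be ordered. The steps away from the cyclohexyl compound are large: an at least 22-fold lower number from compound 1 to compound 2 (1.34 log units; beyond the scatter) and an at least 43-fold lower number from compound 1 to compound 3 (1.63 log units; beyond the scatter). Compound 4 `CSc1cccc(-c2cccc(NC(=O)CCc3cccc4c3B(O)OC4)c2)c1` differs from compound 3 in one place: 3-(methylsulfanyl)phenyl in place of iodo on an aromatic carbon. For the measured compounds named here, no measured step exchanges iodo for a 3-(methylsulfanyl)phenyl group; the only guide is the swap of 4-methylphenyl for 3-iodophenyl, which stayed within the scatter. Compound 4 is therefore expected to land close to its parent, and the estimated step is a 1.5-fold lower number from compound 3 to compound 4 (0.19 log units; within the scatter). The estimate for compound 4 is 1500 nM, ranging from 400 nM to 6000 nM.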

Compound 4, half-maximal inhibitory concentration: 110 nM
For compound 4 the middle estimate is 14-fold (1.13 log units) above the measured one; measured number below the stated range.
By their numbers in this assay, from the lowest: compound 4; then compounds 3 and 2 (each within the scatter of the next). At a limit, above all of these: compound 1.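

In this assay this aromatic carbon proves highly responsive to what it carries: replacing the single iodine atom with 3-(methylsulfanyl)phenyl, which adds a six-membered aromatic ring and a sulfur atom, gives a 21-fold lower number from compound 3 to compound 4 (1.32 log units; beyond the scatter). The earlier exchange between the two aromatic amides, a 2.0-fold lower number from compound 2 to compound 3 (0.29 log units; within the scatter), gave no readable separation, so this is the first change among the aromatic amides shown that goes beyond the scatter. Nothing measured here identifies which part of the entering group accounts for this step.

Going by these compounds, it remains open whether the sulfur matters, or whether an unsubstituted phenyl, a methoxyphenyl or an aminophenyl group would give a similar number on this carbon. Also open, on these data alone, is how a shorter or longer chain between the amide carbonyl and the shared core would affect compound 4.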